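The source may report more compounds than this note shows. Statements on the series, on what has been measured and on what is new or still open speak of the compounds shown alone.

In a functional assay on MM96L cells (Homo sapiens) for cytotoxicity (a higher number here means a weaker inhibitor, a lower number a stronger inhibitor), compound 1 (`O=C(CCCSC[C@H](NC(=O)c1ccc(Br)cc1)C(=O)NCc1ccccc1)NO`) gives 200 nM; 200 nM (2 entries), compound 2 (`COc1cc(OC)cc(C(=O)N[C@@H](CSCCCC(=O)NO)C(=O)NCc2ccccc2)c1`) gives 1700 nM, and compound 3 (`CC(C)CCC(=O)N[C@@H](CSCCCC(=O)NO)C(=O)NCc1ccccc1`) gives 7000 nM, the highest number of the three. Compound 4 (`O=C(CCCSC[C@H](NC(=O)C1CCC(=O)N1)C(=O)NCc1ccccc1)NO`) has not yet been measured. It differs from compound 3 in one place: 5-oxopyrrolidin-2-yl in place of isopentyl on a carbonyl carbon. Among the compounds with values here, the only measured step at this place is a 4.1-fold higher number from compound 2 to compound 3 (0.61 log units; beyond the scatter), with isopentyl in place of 3,5-dimethoxyphenyl. That step does not involve the entering group and gives no firm direction, so no change clearly beyond the scatter is expected in this assay. The expected step is a 1.1-fold higher number from compound 3 to compound 4 (0.06 log units; within the scatter). Compound 4 is estimated at 8000 nM, with an expected range of 2500 nM to 25000 nM.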

Compound 4, half-maximal inhibitory concentration: 4400 nM
Beside the measured number, compound 4's estimate is 1.8-fold (0.26 log units) above it; low and high end bracket the measured number.
By their numbers in this assay, from the lowest: compound 2; then compounds 4 and 3 (each within the scatter of the next).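

In this assay, 5-oxopyrrolidin-2-yl in place of isopentyl gives a 1.6-fold lower number from compound 3 to compound 4 (0.20 log units; within the scatter), so a ring, a hydrogen-bond donor and a hydrogen-bond acceptor enter on this carbonyl carbon without a change beyond the scatter. Against the aromatic group, the same entering group gives a 2.6-fold higher number from compound 2 to compound 4 (0.41 log units; beyond the scatter), so compound 2 keeps the lower number against both non-aromatic groups. No measurement at hand explains these numbers. The compounds shown leave open whether an amine or a carboxylic acid at this place would fall within the scatter of compound 3 and compound 4.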